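A few compounds are considered here, and "the series" means these few. Any claim that something is new, unique, unknown or untested is made for them only; others in the source may bear on it.

Measured so far: compound 1 `CCCCNc1nc(N)nc2c1CNCC2` with 7.2 uM, and compound 2 `CCCCNc1nc(N)nc2c1CN(C(=O)c1ccccn1)CC2` with 2.9 uM.

In an assay on HEK293 cells for agonist activity at Toll-like receptor 8 (Homo sapiens), read by a luciferase reporter, with a stated time of 6 h (on this read-out lower numbers stand for an effect already at smaller amounts and higher numbers for an effect only at larger amounts of compound), compound 2 shows the lowest number of the two. Going by the values given here, the only measured step is a 2.5-fold lower number from compound 1 to compound 2 (0.39 log units; beyond the scatter), which came from (pyridin-2-yl)carbonyl in place of hydrogen on an amine nitrogen in a ring. Compound 3 `CCCCNc1nc(N)nc2c1CN(C(=O)c1csc(C)n1)CC2` differs from compound 2 by 2-methyl-1,3-thiazol-4-yl in place of pyridin-2-yl on a carbonyl carbon. Among the compounds with values here, no measured step swaps one aromatic ring for another on the carbonyl carbon, and the acyl group on the ring nitrogen is kept, so compound 3 is expected to stay close to compound 2, with a 1.0-fold higher number from compound 2 to compound 3 (0.01 log units; within the scatter) expected to lie within the scatter. Compound 3 is therefore estimated at 3 uM, in the range 1 uM to 9 uM.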

Compound 3, minimum effective concentration: 1.8 uM
Beside the measured number, compound 3's estimate is 1.7-fold (0.22 log units) above it; low and high end bracket the measured number.
By their numbers in this assay, from the lowest: compounds 3 and 2 (each within the scatter of the next); then compound 1.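

In this assay, the ring on the carbonyl carbon can change with little effect: the step is a 1.6-fold lower number from compound 2 to compound 3 (0.21 log units; within the scatter), so the five-membered 2-methyl-1,3-thiazol-4-yl ring and the six-membered pyridin-2-yl ring cannot be told apart here. A second acyl group on the ring nitrogen also improves on the free amine, with a 4.0-fold lower number from compound 1 to compound 3 (0.60 log units; beyond the scatter). No measurements are available to explain these results.

Still open, as far as these compounds go, is whether an acetyl group or a non-aromatic cyclohexyl ring on the carbonyl carbon would do as well. From the compounds shown here alone, the contribution of the thiazole's methyl group also remains unknown.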